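This account rests on a few compounds, and the source may have more. Where it says the series, first, only, none or still open, it means among the compounds named here.

In an assay on membranes from cerebellum for inhibition of Monoglyceride lipase (Rattus norvegicus), tested at 100 uM (on this read-out higher numbers stand for more inhibition at the one concentration tested (going by the name of the read-out) and lower numbers for less inhibition), compound 1, `CCCCC/C=C\C/C=C\C/C=C\C/C=C\CCCC(=O)OC[C@@H]1COC(C)(C)O1`, gives 38%, and compound 2, `CCCCCCCC/C=C\CCCCCCCC(=O)OCC1CCCCO1`, gives 35%. Only these two numbers exist, and compound 2 sits within the usual scatter of compound 1, so the two show no real difference between them. Compound 3, `CC/C=C\C/C=C\C/C=C\CCCCCCCC(=O)OCC1CCCCO1`, differs from compound 2 by hepta-1,4-dien-1-yl in place of heptyl on a saturated chain carbon bound to a double-bonded chain carbon. Because compound 1 with more double bonds gives 38%, close to compound 2, the estimated step of a number 2 percentage points higher from compound 2 to compound 3 (within the scatter) is expected to stay within the scatter. Compound 3 is estimated to give 37%, with a range from 25% to 50%.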

Compound 3, a percentage reported as inhibition, at one concentration (the size of the read-out at that concentration, not a potency): 33%
Estimate against measurement, compound 3: 4 percentage points above; the range from low to high includes it.
By their numbers in this assay, from the lowest: compounds 3, 2 and 1 (each within the scatter of the next).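

The step for hepta-1,4-dien-1-yl in place of heptyl on a saturated chain carbon bound to a double-bonded chain carbon is a number 2 percentage points lower from compound 2 to compound 3 (within the scatter) in this assay. For the compounds shown here, this is the first comparison here that differs in one place, and it shows that adding these double bonds at this position makes no real difference to the read-out. Nothing available explains this result. On these data alone, whether a longer chain or an amine at this position would give a real difference remains open.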